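The source may report more compounds than this note shows. Statements on the series, on what has been measured and on what is new or still open speak of the compounds shown alone.

Two compounds in the series carry a number in a functional assay on PC-12 cells (Rattus norvegicus) for cytotoxicity, read by MTT assay, with stated times of 3 h and 2 h, tested at 1 uM; a lower number here means a weaker effect, a higher number a stronger effect of the compound at the concentration tested. Compound 1 `CCOC(=O)c1cc2ccc(OCCCn3cc(CNC(=O)CCCCC4CCSS4)nn3)cc2oc1=O` gives 28.3% there. Compound 2 `O=C(CCCCC1CCSS1)NCc1cn(CCCCOc2ccc3ccc(=O)oc3c2)nn1` gives 45.9% in this assay, the higher of the two, with compound 1 lower by a gap beyond the scatter. Compound 3 `O=C(CCCCC1CCSS1)NCc1cn(CCCCOc2ccc3cc(-c4ccc(Br)cc4)c(=O)oc3c2)nn1` is not yet measured; it differs from compound 2 by 4-bromophenyl in place of hydrogen on an aromatic carbon. Within the data shown here, no step between measured compounds bears on this change, so the direction rests on compound 2 alone. A modest rise is expected, the step from compound 2 to compound 3 being estimated at a number 6.1 percentage points higher from compound 2 to compound 3 (within the scatter). For compound 3 the expected value in this assay is 52%, within 35% to 70%.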

Compound 3, a percentage reported as activity, at one concentration (the size of the read-out at that concentration, not a potency): 37.4%
Compound 3: middle estimate off by 14.6 percentage points, on the high side; measured number inside the range.
By their numbers in this assay, from the lowest: compounds 1, 3 and 2 (each within the scatter of the next, the first and the last beyond it).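

In this assay, 4-bromophenyl in place of hydrogen on this aromatic carbon, two atoms from the ring oxygen, gives a number 8.5 percentage points lower from compound 2 to compound 3 (within the scatter). Among these compounds, this position therefore carries an added aromatic ring with no step beyond the scatter, a first reading at this place. No available data explain this result.

Open, going by these compounds, is whether the bromine or the phenyl ring accounts for this reading, which unsubstituted phenyl or 4-chlorophenyl at the same carbon could separate. On these data alone, the effect of an amine or a carboxylic acid on this carbon also remains open.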